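Removal of the acrylamide warhead on a second core

The source may hold more compounds than are shown below. What is called first, only, known or untested is meant among the compounds shown, and "the series" means these compounds.

Compound 1 `C=C(Br)C(=O)Nc1cccc(-c2cn3nc(Cc4cccc(OC)c4)sc3n2)c1` and compound 3 `C=C(Br)C(=O)Nc1cccc(-c2cn3nc(-c4ccc(Cl)cc4)sc3n2)c1` carry the same (1-bromoethenyl)carbonyl group on an aromatic nitrogen and differ only in the core, where (4-chlorophenyl in place of 3-methoxybenzyl on an aromatic carbon); in a functional assay on CCRF-CEM cells (Homo sapiens) for inhibition, read by cell counting, with a stated time of 3 days (a lower number here means a stronger inhibitor, a higher number a weaker inhibitor), compound 1 gives 3100 nM and compound 3 gives 3200 nM, so that a 1.0-fold higher number from compound 1 to compound 3 (0.01 log units; within the scatter). Compound 2 `COc1cccc(Cc2nn3cc(-c4cccc(N)c4)nc3s2)c1` is compound 1 stripped of that group, (hydrogen in place of (1-bromoethenyl)carbonyl on a nitrogen on an aromatic ring), and in this assay compound 2 gives 40000 nM; the step is a 13-fold higher number from compound 1 to compound 2 (1.11 log units; beyond the scatter).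

Compound 4 `Nc1cccc(-c2cn3nc(-c4ccc(Cl)cc4)sc3n2)c1` is the matching stripped form of compound 3, (hydrogen in place of (1-bromoethenyl)carbonyl on a nitrogen on an aromatic ring); the group that leaves, the hydrogen that enters and the place are the same as in the change from compound 1 to compound 2, so this is the same change on the other core. Going by the values given here, since the two cores gave the same number with the warhead in place (a 1.0-fold higher number from compound 1 to compound 3 (0.01 log units; within the scatter)), the expectation for compound 4 rests on the single measured step of a 13-fold higher number from compound 1 to compound 2 (1.11 log units; beyond the scatter), and a step of about a 13-fold higher number from compound 3 to compound 4 (1.10 log units; beyond the scatter) is expected. Compound 4 is therefore estimated at 40000 nM in this assay, with a range of 15000 nM to 100000 nM.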

Compound 4, half-maximal inhibitory concentration: > 250000 nM
Compound 4: only a limit was reported; the forecaster's own chance of this, stated with the estimate: 20%; middle value at least 6.2-fold (0.79 log units) from the limit.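

Removing the (1-bromoethenyl)carbonyl group gives an at least 78-fold higher number from compound 3 to compound 4 (1.89 log units; beyond the scatter), the same direction as on the core of compound 1, but the size of the step does not carry over unchanged: the same change on two cores in this assay, a 13-fold higher number (1.11 log units; beyond the scatter) from compound 1 to compound 2 and an at least 78-fold higher number (1.89 log units; beyond the scatter) from compound 3 to compound 4, at least 6.0-fold (0.78 log units) apart, beyond the scatter of two such steps

In this assay compound 4 gives > 250000 nM, which is a limit of the assay and not a number: the limit of > 250000 nM in this assay, at which 1 of the 4 values shown sits.

The gap between the two steps therefore has only a lower bound, and two matched pairs show neither its true size nor a rule for the wider series.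

The compounds shown leave open how a propanoyl group or an unsubstituted acryloyl group on the same nitrogen would compare with (1-bromoethenyl)carbonyl on either core. They also leave open whether the larger step follows the 4-chlorophenyl group itself, as a plain phenyl or a 4-chlorobenzyl group in its place could help to show.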